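Taking the methyl off compound 2

The source may hold more compounds than are shown below. What is called first, only, known or untested is meant among the compounds shown, and "the series" means these compounds.

Of the compounds shown here, two have numbers so far. In a functional assay on MDA-MB-435 cells (Homo sapiens) for inhibition, read by sulforhodamine B assay, with a stated time of 48 h (on this read-out higher numbers stand for weaker inhibition and lower numbers for stronger inhibition), compound 1 (`COc1ccc(N(C)c2ncnc3c2CCC3)cc1`) gives 43 nM and compound 2 (`CCOc1ccc(N(C)c2nc(C)nc3c2CCC3)cc1`) gives 15.1 nM as the lower of the two numbers. That gap lies beyond the usual scatter, but these two compounds differ in more than one place, so it cannot be assigned to any single change.

Compound 3 (`CCOc1ccc(N(C)c2ncnc3c2CCC3)cc1`) has hydrogen in place of methyl on an aromatic carbon, between two ring nitrogen atoms, and the counted difference from compound 2 is hydrogen in place of methyl on an aromatic carbon in full. Among the compounds with values here, no measured step isolates this change. Within the data shown here, compound 1, which also has hydrogen on that carbon, stands at 43 nM as the only reading without the methyl. On that basis, a step to a higher number in this assay is expected, meaning weaker inhibition, of a size modestly beyond the scatter. The expected size is a 2.6-fold higher number from compound 2 to compound 3 (0.42 log units; beyond the scatter) on this estimate. For compound 3 the estimated value is 40 nM with an expected range from 15 nM to 110 nM as its bounds.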

Compound 3, half-maximal inhibitory concentration: 48.7 nM
Compound 3: middle estimate off by 1.2-fold (0.09 log units), on the low side, and the stated range covers the measured number.
By their numbers in this assay, from the lowest: compound 2; then compounds 1 and 3 (each within the scatter of the next).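

In this assay the methyl on the aromatic carbon between two ring nitrogen atoms now has a reading as a single change: hydrogen in its place gives a 3.2-fold higher number from compound 2 to compound 3 (0.51 log units; beyond the scatter) as a modest step, so this pair links loss of the methyl alone to weaker inhibition. With hydrogen on that carbon, methyl in place of hydrogen on the saturated chain carbon bound to an oxygen on an aromatic ring gives a 1.1-fold higher number from compound 1 to compound 3 (0.05 log units; within the scatter) and so makes no difference that can be told from the scatter, which places the earlier gap between compound 1 and compound 2 with the aromatic methyl rather than the chain, as far as these three compounds go. Nothing available here offers an explanation for the methyl step.

The compounds shown leave open whether the chain change would also stay within the scatter with methyl present on the aromatic carbon, since that comparison needs a further compound. They also leave open how an ethyl, a trifluoromethyl or an amine on that carbon would compare with methyl and hydrogen.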